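The source may hold more compounds than are shown below. What is called first, only, known or untested is meant among the compounds shown, and "the series" means these compounds.

Compound 1 `O=c1nc(N2CC[C@@H](c3ccc(F)cc3)[C@H](O)C2)sc2c([N+](=O)[O-])cc(C(F)(F)F)cc12` gives 68400 nM in a toxicity assay on HeLa cells (Homo sapiens) for cytotoxicity, read by colorimetric assay, with a stated time of 72 h; a higher number here means that more compound is tolerated, a lower number that less compound is tolerated.
Compound 2 `CN(C(=O)CN1CCN(c2nc(=O)c3cc(C(F)(F)F)cc([N+](=O)[O-])c3s2)CC1)c1ccccc1` gives 70300 nM in this assay.
Compound 3 `CN1CCN(C(=O)C(F)(F)C(F)(F)C(=O)N2CCN(c3nc(=O)c4cc(C(F)(F)F)cc([N+](=O)[O-])c4s3)CC2)CC1` gives > 81400 nM in this assay.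

All three share the same core. Compound 1 and compound 2 sit close together in this assay, within the usual scatter of each other, so no order between them can be claimed. For compound 3 the assay reports not a number but a limit: compound 3 shows only > 81400 nM. This is the situation marked by the limit of > 81400 nM in this assay, at which 1 of the 3 values shown sits, so compound 3 stands at the upper edge of what this assay can report, among the best-tolerated of the three.

Compound 4 `CN1CCN(C(=O)C(F)(F)C(F)(F)C(F)(F)C(=O)N2CCN(c3nc(=O)c4cc(C(F)(F)F)cc([N+](=O)[O-])c4s3)CC2)CC1` differs from compound 3 in a single place: difluoro((4-methylpiperazin-1-yl)carbonyl)methyl in place of (4-methylpiperazin-1-yl)carbonyl on a saturated chain carbon bound to two fluorine atoms and a saturated chain carbon. The linker between the two ends of the molecule grows by one more saturated carbon bound to two fluorine atoms; everything else stays as in compound 3. Going by the values given here, no measured step of this kind exists among the three compounds, and since all three already sit in one narrow band of this assay, no movement beyond the scatter is expected. The step from compound 3 to compound 4 is estimated at a step that the limit leaves unreadable from compound 3 to compound 4, essentially none. Compound 4 is therefore expected to give about 85000 nM in this assay, with a likely range from 45000 nM to 160000 nM, and quite possibly again only a limit rather than a number.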

Compound 4, half-maximal cytotoxic concentration: > 75200 nM
Compound 4: no number, only a limit; the forecaster's own chance of this, stated with the estimate: 65%; the middle value is on the limit's open side.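

Going by these compounds alone, compound 3 and compound 4 each give only a limit in this assay, not a number, so no step between them can be read. The compounds shown leave open whether the added difluoromethylene unit in the linker of compound 4 changes how well the compound is tolerated.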